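The source may hold more compounds than are shown below. What is called first, only, known or untested is meant among the compounds shown, and "the series" means these compounds.

Working notes on the series of amides tested in an assay on isolated protein (Aquatica lateralis) for inhibition of Luciferin 4-monooxygenase (Luciola lateralis), read by a luciferase reporter, tested at 10 uM; on this read-out lower numbers stand for less inhibition and higher numbers for more inhibition at the one concentration tested (going by the name of the read-out).

Compound 1, `O=C(Nc1ccccn1)c1ccccc1`, is the unsubstituted parent and in this assay gives 27%. Compound 2, `O=C(Nc1cccc(-c2ccccc2)n1)c1ccccc1`, carries a phenyl on an aromatic carbon of the same core and gives 30%. Compound 3, `O=C(Nc1ccc(-c2ccccc2)cn1)Oc1ccccc1`, replaces the benzamide by a phenyl carbamate and also carries a phenyl; it gives 0%. On these three numbers compound 1 stands second highest: its nearest neighbour is compound 2, within the scatter of it, and its furthest is compound 3, beyond the scatter.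

The step to be judged leads from compound 1 to compound 4, `Cc1ccc(-c2ccc(NC(=O)c3ccccc3)nc2)cc1`. The change is 4-methylphenyl in place of hydrogen on an aromatic carbon. Going by the values given here, the only measured single-place step is a number 3 percentage points higher from compound 1 to compound 2 (within the scatter), which put a phenyl onto the core without moving the number beyond the scatter. Compound 3 carries its phenyl at the same place as compound 4 but differs from compound 1 in the amide as well, so its low value cannot be assigned to the aryl group alone. For compound 4 a step of about a number 2 percentage points lower from compound 1 to compound 4 (within the scatter) is therefore expected, that is no change beyond the scatter, with compound 3 as a reason for some caution toward lower numbers. Compound 4 is expected at 25%, within 5% to 45%.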

Compound 4, a percentage reported as inhibition, at one concentration (the size of the read-out at that concentration, not a potency): 51%
The estimate for compound 4 lay 26 percentage points below the measured number; measured number above the stated range.
By their numbers in this assay, from the lowest: compound 3; then compounds 1 and 2 (each within the scatter of the next); then compound 4.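

In this assay, 4-methylphenyl in place of hydrogen gives a number 24 percentage points higher from compound 1 to compound 4 (beyond the scatter). Going by these compounds alone, this is the first single-place change with a step beyond the scatter, and it sits on an aromatic carbon two atoms from the ring nitrogen and para to a group of 9 heavy atoms. The earlier step, a number 3 percentage points higher from compound 1 to compound 2 (within the scatter), also added an aromatic ring to the core but stayed within the scatter, so adding such a ring does not always give a step of this size, and the data shown offer no measured explanation for the higher number.

As far as these compounds go, it remains open whether this higher number depends on the methyl or would also appear with an unsubstituted phenyl at this place, and whether a methoxy, an amine or a carboxylic acid in place of the methyl would keep, raise or lower it. Also open, from the compounds shown here alone, is whether the result holds beyond the one concentration tested, and whether it would survive replacing the benzamide with a urea or a sulfonamide.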